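The compounds below may be only part of what the source reports. "The series", "measured", "known", "first", "only" and "open" are said of these compounds alone.

Two compounds from the same series, built on one shared core, have been tested so far. Compound 1 `C=C1C[C@]23C[C@@]1(O)CC[C@@H]2c1cccc(C)c1[C@@H]3Cn1cc(-c2ccc(Cl)cc2)nn1` carries a 4-chlorophenyl group on the triazole ring. In a functional assay on A549 cells (Homo sapiens) for cytotoxicity, read by MTT assay, with a stated time of 4 days (on this read-out lower numbers stand for stronger inhibition and higher numbers for weaker inhibition), compound 1 gives > 20000 nM, which is a limit of the assay rather than a number. Compound 2 `C=C1C[C@]23C[C@@]1(O)CC[C@@H]2c1cccc(C)c1[C@@H]3Cn1cc(-c2ccccn2)nn1` differs from it by having pyridin-2-yl in place of 4-chlorophenyl on an aromatic carbon. In this assay compound 2 gives > 20000 nM, again a limit and not a number. The step that the two limits leave unreadable from compound 1 to compound 2 therefore cannot be sized; both values sit at the limit of > 20000 nM in this assay, at which 2 of the 2 values shown sit, so compound 2 stands where compound 1 stands, at the edge of what the assay can report.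

Compound 3 `C=C1C[C@]23C[C@@]1(O)CC[C@@H]2c1cccc(C)c1[C@@H]3Cn1cc(-c2ccc(F)cc2)nn1` is not yet measured. It differs from compound 2 in one place: 4-fluorophenyl in place of pyridin-2-yl on an aromatic carbon. Within the data shown here, the only measured step, a step that the two limits leave unreadable from compound 1 to compound 2, offers no readable size, and the sole evidence is that both neighbours rest at the limit of > 20000 nM in this assay, at which 2 of the 2 values shown sit. No step beyond the scatter is expected in either direction. Compound 3 is therefore estimated at 30000 nM, with a range from 10000 nM to 100000 nM, most likely reported once more as a limit. The expected step is a step that the limit leaves unreadable from compound 2 to compound 3.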

Compound 3, half-maximal inhibitory concentration: > 20000 nM
Compound 3: a limit, no number (the forecaster's own chance of this, stated with the estimate: 80%); the middle value does not contradict the limit.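

In this assay compound 3 gives > 20000 nM, a limit and not a number. No step among compound 1, compound 2 and compound 3 can be read, because all three rest at one limit: the limit of > 20000 nM in this assay, at which 3 of the 3 values shown sit.

What remains open is how the 4-chlorophenyl, pyridin-2-yl and 4-fluorophenyl groups compare, since none of these compounds has a numerical value.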